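Chain length at the amide nitrogen in a sirtuin-6 series

The source may hold more compounds than are shown below. What is called first, only, known or untested is meant among the compounds shown, and "the series" means these compounds.

Measured compounds:
compound 1 `CCCCCCCCCCNC(=O)CCCSC[C@H](NC(=O)OCc1ccccc1)C(=O)Nc1ccccc1`, 28%
compound 2 `CCCCCCCCCCCCCNC(=O)CCCSC[C@H](NC(=O)OCc1ccccc1)C(=O)Nc1ccccc1`, 31%
compound 3 `CCCCNC(=O)CCCSC[C@H](NC(=O)OCc1ccccc1)C(=O)Nc1ccccc1`, 26%

In an assay for inhibition of NAD-dependent protein deacylase sirtuin-6 (Homo sapiens), read by HPLC, with stated times of 15 min and 1 h, tested at 333 uM (a higher number here means more inhibition at the concentration tested (going by the name of the read-out), a lower number less inhibition), compound 1 gives 28%, the second highest of the three numbers; its nearest neighbour is compound 3, and the furthest is compound 2. The steps among the measured compounds are all small: a number 3 percentage points higher from compound 1 to compound 2 (within the scatter), a number 2 percentage points lower from compound 1 to compound 3 (within the scatter) and a number 5 percentage points lower from compound 2 to compound 3 (within the scatter). Lengthening or shortening the saturated chain on the amide-type nitrogen between butyl and tridecyl therefore leaves the read-out unchanged within the scatter.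

Compound 4 `CNC(=O)CCCSC[C@H](NC(=O)OCc1ccccc1)C(=O)Nc1ccccc1` is not yet measured. It differs from compound 1 as follows: hydrogen in place of nonyl on a saturated chain carbon bound to an amide-type nitrogen. Among the compounds with values here, this cut goes further than any measured step, down to the smallest chain, so no measured pair covers it directly; the closest analogies are the steps to compound 3, which were within the scatter. On this basis compound 4 is expected to show a step of a number 3 percentage points lower from compound 1 to compound 4 (within the scatter) in this assay, that is, no change beyond the scatter. The estimated value for compound 4 is 25%, with a range from 12% to 38%.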

Compound 4, a percentage reported as inhibition, at one concentration (the size of the read-out at that concentration, not a potency): "not active" (no number reported)
Compound 4 has no reported number here, so the estimate cannot be set against anything.
By their numbers in this assay, from the lowest: compounds 3, 1 and 2 (each within the scatter of the next).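

Within the data shown here, compound 4 is recorded as "not active" in this assay, without a number, so no step from compound 1, compound 2 or compound 3 to compound 4 can be read. No data shown bear on a cause for this result. The compounds shown leave open whether methyl in place of decyl truly separates compound 4 from compound 1 in this assay.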